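The compounds below may be only part of what the source reports. "The series", "measured", "known", "first", "only" and "open" are said of these compounds alone.

Working notes on the series. The parent is compound 1 `O=S(=O)(Cc1ccccc1)c1nc(-c2ccccc2)c(-c2ccccc2)[nH]1`. In an ADME assay on S9 fraction from liver (Cricetinae) for metabolic stability (on this read-out lower numbers stand for a shorter-lived compound and higher numbers for a longer-lived compound), compound 1 gives < 0.0417 h, which is a limit of the assay rather than a number. Compound 2 `Cn1c(S(=O)(=O)Cc2ccccc2)nc(-c2ccccc2)c1-c1ccccc1` carries a methyl in place of hydrogen on an aromatic nitrogen. In this assay compound 2 gives < 0.0417 h, again a limit. The step that the two limits leave unreadable from compound 1 to compound 2 therefore cannot be sized; both values sit at the limit of < 0.0417 h in this assay, at which 2 of the 2 values shown sit. Compound 3 `Cn1c(S(=O)(=O)C(F)c2ccc(F)cc2)nc(-c2ccccc2)c1-c1ccccc1` differs from compound 2 by fluoro(4-fluorophenyl)methyl in place of benzyl on a sulfonyl sulfur. Within the data shown here, no measured step bears on this change, and compound 2 stands only at a limit. The step of an at least 1.1-fold higher number from compound 2 to compound 3 (0.07 log units; that floor lies within the scatter) is expected to be small. Compound 3 is estimated at 0.05 h, range 0.02 h to 0.2 h.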

Compound 3, half-life: < 0.0417 h
Compound 3 gave a limit, no number; the forecaster's own chance of this, stated with the estimate: 60%; middle value at least 1.1-fold (0.07 log units) from the limit.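

Compound 2 and compound 3 both give limits rather than numbers, so no step between them can be read: the limit of < 0.0417 h in this assay, at which 3 of the 3 values shown sit.

The compounds shown leave open the actual half-life of each compound in this assay, and whether fluoro(4-fluorophenyl)methyl in place of benzyl changes it at all.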